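Series notes: the step from compound 3 to compound 4

The source may hold more compounds than are shown below. What is called first, only, known or untested is meant among the compounds shown, and "the series" means these compounds.

Measured so far in a functional assay on A549 cells (Homo sapiens) for antiproliferative activity, read by MTT assay, with a stated time of 72 h; on this read-out lower numbers stand for stronger inhibition and higher numbers for weaker inhibition:
- compound 1 `NS(=O)(=O)c1ccc(NC(=S)Nc2ccc3ncnc(Nc4cccc(Br)c4)c3c2)cc1` gives 25000 nM
- compound 2 `NS(=O)(=O)c1ccc(NC(=S)Nc2ccc3ncnc(Nc4cccc(Cl)c4F)c3c2)cc1` gives only a limit, > 40000 nM
- compound 3 `Cc1cccc(Nc2ncnc3ccc(NC(=S)Nc4ccc(S(N)(=O)=O)cc4)cc23)c1` gives only a limit, > 40000 nM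

Compound 3 therefore stands at a limit of this assay and not at a number; two of the three values shown sit there (the limit of > 40000 nM in this assay, at which 2 of the 3 values shown sit). The two steps that reach compound 3 are an at least 1.6-fold higher number from compound 1 to compound 3 (0.20 log units; that floor lies within the scatter) and a step that the two limits leave unreadable from compound 2 to compound 3, neither readable beyond the scatter.

Compound 4 `CCc1ccc(Nc2ncnc3ccc(NC(=S)Nc4ccc(S(N)(=O)=O)cc4)cc23)cc1` differs from compound 3 by 4-ethylphenyl in place of 3-methylphenyl on a nitrogen on an aromatic ring. For the measured compounds named here, no measured step touches this group, so the record gives no direction. Compound 4 is expected to remain at the limit; the estimate is 50000 nM, from 20000 nM to 150000 nM, with a step that the limit leaves unreadable from compound 3 to compound 4 expected to be none beyond the scatter.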

Compound 4, half-maximal inhibitory concentration: 24600 nM
Compound 4: middle estimate off by 2.0-fold (0.31 log units), on the high side; the range from low to high includes it.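

Compound 4 is the second compound in this assay with a number and not a limit, so an aryl group other than 3-bromophenyl on this nitrogen can leave the limit: the limit of > 40000 nM in this assay, at which 2 of the 4 values shown sit. Against the two limits, the readings are only floors: an at least 1.6-fold lower number from compound 3 to compound 4 (0.21 log units; that floor lies within the scatter), and an at least 1.6-fold lower number from compound 2 to compound 4 (0.21 log units; that floor lies within the scatter). Against the other number, the reading is a 1.0-fold lower number from compound 1 to compound 4 (0.01 log units; within the scatter), so 4-ethylphenyl and 3-bromophenyl cannot be told apart here.

Both the chain and its place on the ring change in the step from compound 3, so neither can be credited alone. As far as these compounds go, how a longer chain or an amine on this phenyl ring would read stays open.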